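Pyrazole regioisomer at the methylated ring of compound 2

The compounds below may be only part of what the source reports. "The series", "measured", "known", "first", "only" and "open" are said of these compounds alone.

Two members of the series have numbers in a functional assay on CHO cells for antagonist activity at sphingosine 1-phosphate receptor 2 (Homo sapiens), read by fluorescence and calcium flux, with a stated time of 3 min (on this read-out higher numbers stand for weaker inhibition and lower numbers for stronger inhibition), so far. Compound 1 `Cc1cc(NNC(=O)Nc2cc(Cl)nc(Cl)c2)ncc1C#N` gives 6000 nM in this assay. Going by the values given here, compound 2 `Cc1cc(NNC(=O)Nc2cc(Cl)nc(Cl)c2)ncc1-c1cnn(C)c1` gives 2600 nM in this assay, the lowest of the two numbers; the only step recorded, a 2.3-fold lower number from compound 1 to compound 2 (0.36 log units; beyond the scatter), separates it from compound 1. Compound 3 `Cc1cc(NNC(=O)Nc2cc(Cl)nc(Cl)c2)ncc1-c1ccn(C)n1` has not yet been measured in this assay. It differs from compound 2 by 1-methyl-1H-pyrazol-3-yl in place of 1-methyl-1H-pyrazol-4-yl on an aromatic carbon. Among the compounds with values here, no measured step addresses an exchange of one pyrazolyl attachment for the other; the single recorded step concerns cyano against the pyrazolyl group and does not transfer to compound 3. With nothing to support a direction, compound 3 is expected to stay within the scatter of compound 2, an estimated step of a 1.2-fold higher number from compound 2 to compound 3 (0.06 log units; within the scatter). The estimate for compound 3 in this assay is therefore 3000 nM, with a range from 1200 nM to 8000 nM.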

Compound 3, half-maximal inhibitory concentration: 4000 nM
For compound 3 the middle estimate is 1.3-fold (0.12 log units) below the measured one; the range from low to high includes it.
By their numbers in this assay, from the lowest: compounds 2, 3 and 1 (each within the scatter of the next, the first and the last beyond it).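

In this assay, moving the attachment from 1-methyl-1H-pyrazol-4-yl to 1-methyl-1H-pyrazol-3-yl on this aromatic carbon gives a 1.5-fold higher number from compound 2 to compound 3 (0.19 log units; within the scatter), so the position does not separate these two regioisomers. Against the nitrile, the 3-yl isomer shows a 1.5-fold lower number from compound 1 to compound 3 (0.18 log units; within the scatter), whereas the 4-yl isomer showed a 2.3-fold lower number from compound 1 to compound 2 (0.36 log units; beyond the scatter); the separation from compound 1 therefore holds for compound 2 but not for compound 3, although compound 2 and compound 3 cannot themselves be told apart. No available data explain these numbers.

As far as these compounds go, it remains open whether a carboxylic acid, an amine or a longer alkyl chain at this position would give a number beyond the scatter of all three compounds. From the compounds shown here alone, the effect of removing the pyrazole N-methyl group is also open.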